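A few compounds are considered here, and "the series" means these few. Any claim that something is new, unique, unknown or untested is made for them only; others in the source may bear on it.

Within the series, compound 1 `CC(C)=Cc1c(-c2ccccc2)sc(C(C)C)c1/C=C/[C@@H](O)C[C@@H](O)CC(=O)O` gives 1000 nM in an assay on microsomes for inhibition of 3-hydroxy-3-methylglutaryl-coenzyme A reductase (Rattus norvegicus) (a higher number here means a weaker inhibitor, a lower number a stronger inhibitor), compound 2 `CC(C)c1sc(-c2ccccc2)c(-c2cccc(C(F)(F)F)c2)c1/C=C/[C@@H](O)C[C@@H](O)CC(=O)O` gives 2980 nM, and compound 3 `CC(C)c1sc(-c2ccccc2)c(-c2cccc(F)c2)c1/C=C/[C@@H](O)C[C@@H](O)CC(=O)O` gives 49 nM, the lowest of the three numbers. Compound 4 `COc1ccc(-c2c(-c3ccccc3)sc(C(C)C)c2/C=C/[C@@H](O)C[C@@H](O)CC(=O)O)cc1` differs from compound 3 by 4-methoxyphenyl in place of 3-fluorophenyl on an aromatic carbon. The bearing steps are the changes at this aromatic carbon: a 20-fold lower number from compound 1 to compound 3 (1.31 log units; beyond the scatter) and a 61-fold lower number from compound 2 to compound 3 (1.78 log units; beyond the scatter), both large, showing this position to be sensitive and the 3-fluorophenyl the best group so far. Among the measured compounds shown here, with no direct precedent for 4-methoxyphenyl, the expectation for compound 4 is a modest to large rise, an 8.2-fold higher number from compound 3 to compound 4 (0.91 log units; beyond the scatter), giving an estimated 400 nM with a range of 100 nM to 2000 nM.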

Compound 4, half-maximal inhibitory concentration: 2430 nM
Estimate against measurement, compound 4: 6.1-fold (0.78 log units) below; measured number outside the range, above it.
By their numbers in this assay, from the lowest: compound 3; then compound 1; then compounds 4 and 2 (each within the scatter of the next).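

In this assay the loss at this carbon is not confined to trifluoromethyl: a 50-fold higher number from compound 3 to compound 4 (1.70 log units; beyond the scatter) shows that a second substituted phenyl also falls far short of 3-fluorophenyl. The steps of a 1.2-fold lower number from compound 2 to compound 4 (0.09 log units; within the scatter) and a 2.4-fold higher number from compound 1 to compound 4 (0.39 log units; beyond the scatter) place 4-methoxyphenyl level with 3-(trifluoromethyl)phenyl and weaker than 2-methylprop-1-en-1-yl. Nothing at hand explains this drop.

Compound 3 and compound 4 differ in both the substituent and its place on the phenyl ring, so the two effects cannot be separated. 4-Fluorophenyl and 3-methoxyphenyl would pull them apart.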